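The source may hold more compounds than are shown below. What is called first, only, known or untested is meant among the compounds shown, and "the series" means these compounds.

Working notes on a series of four urea compounds. Compound 1 `COc1cc(-c2nc3ccc(F)cn3c2NC2CCCCC2)ccc1OCCCNC(=O)Nc1ccc(OC(F)(F)F)cc1` and compound 2 `COc1cc(-c2nc3ccc(F)cn3c2NC2CCCCC2)ccc1OCCCNC(=O)Nc1ccc(C(F)(F)F)cc1` share one core; compound 3 `COc1cc(-c2nc3ccc(C)cn3c2NC2CCCC2)ccc1OCCCNC(=O)Nc1ccc(OC(F)(F)F)cc1` and compound 4 `COc1cc(-c2nc3ccc(C)cn3c2NC2CCCC2)ccc1OCCCNC(=O)Nc1ccc(C(F)(F)F)cc1` share another, and the difference between the two cores is not broken down here. In an assay for inhibition of Polyunsaturated fatty acid 5-lipoxygenase (Homo sapiens), read by HPLC, with a stated time of 15 min (on this read-out higher numbers stand for weaker inhibition and lower numbers for stronger inhibition), compound 1 gives 696 nM. In this assay compound 2 gives 649 nM, and the change trifluoromethyl in place of trifluoromethoxy on an aromatic carbon makes a 1.1-fold lower number from compound 1 to compound 2 (0.03 log units; within the scatter). In this assay compound 3 gives 473 nM, a value that lies within the scatter of both compound 1 and compound 2, so no order among the three is drawn. Compound 4 differs from compound 3 by trifluoromethyl in place of trifluoromethoxy on an aromatic carbon, the same change as between compound 1 and compound 2. Among the measured compounds shown here, the step of a 1.1-fold lower number from compound 3 to compound 4 (0.03 log units; within the scatter) is expected to be about as small, resting on the single earlier instance a 1.1-fold lower number from compound 1 to compound 2 (0.03 log units; within the scatter). Compound 4 is therefore estimated at 440 nM, with a range of 250 nM to 800 nM.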

Compound 4, half-maximal inhibitory concentration: 614 nM
Estimate against measurement, compound 4: 1.4-fold (0.14 log units) below; the range from low to high includes it.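

In this assay, trifluoromethyl in place of trifluoromethoxy gives a 1.3-fold higher number from compound 3 to compound 4 (0.11 log units; within the scatter), so on this core too the step stays within the scatter. Set beside the earlier instance, the two steps do not differ: the same change on two cores in this assay, a 1.1-fold lower number (0.03 log units; within the scatter) from compound 1 to compound 2 and a 1.3-fold higher number (0.11 log units; within the scatter) from compound 3 to compound 4, 1.4-fold (0.14 log units) apart, within the scatter of two such steps. Among the compounds shown here, the change therefore carries between these two cores as a step too small to read, but this rests on only two pairs in one assay and does not show that it would stay as small on any other core.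

The compounds shown leave open how an amine or a carboxylic acid in place of trifluoromethyl on the phenyl ring would read. Also open, from the compounds shown here alone, is how a longer chain between the urea and the methoxy-bearing ring would read.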